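The compounds below may be only part of what the source reports. "The series", "measured", "known", "first", "only" and "open" are said of these compounds alone.

Compound 1 `COc1cccc(OC)c1C(=O)Nc1c[nH]nc1C(=O)NCCCOC(C)C` — > 50000 nM
Compound 2 `CO[C@H]1CC[C@H](NC(=O)c2n[nH]cc2NC(=O)c2ccc(F)cc2F)CC1` — 11000 nM
Compound 3 `CO[C@H]1CC[C@H](NC(=O)c2n[nH]cc2NC(=O)c2ccc(-c3ccccc3)o2)CC1` — 100 nM

In an ADME assay on MRC5 cells (Homo sapiens) for inhibition, with a stated time of 72 h (a higher number here means that more compound is needed for the effect, a lower number that less compound is needed), compound 1 gives > 50000 nM, which is a limit of the assay and not a number. Compound 1 sits at the limit of > 50000 nM in this assay, at which 1 of the 3 values shown sits. Alongside it, compound 2 gives 11000 nM and compound 3 gives 100 nM in this assay. Compound 4 `COC(=O)c1n[nH]cc1NC(=O)c1c(OC)cccc1OC` has not yet been measured. It differs from compound 1 in one place (methoxy in place of (3-isopropoxypropyl)amino on a carbonyl carbon). Within the data shown here, no step between measured compounds is available for comparison, so the expectation rests on the change alone: the estimated step from compound 1 to compound 4 in this assay is a number no higher from compound 1 to compound 4 (the limit leaves the size open), none beyond the usual scatter, with a limit again the likely outcome. Compound 4 is expected to give 50000 nM, within 15000 nM to 200000 nM.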

Compound 4, half-maximal effective concentration: > 50000 nM
Compound 4 was reported as a limit; the forecaster's own chance of this, stated with the estimate: 70%; the middle value sits exactly at the limit.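

Compound 1 and compound 4 both give a limit and not a number in this assay, so no step can be read between them. As far as these compounds go, how far methoxy in place of (3-isopropoxypropyl)amino shifts the value on the shared core stays open.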